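The source may hold more compounds than are shown below. What is called first, only, known or untested is meant among the compounds shown, and "the series" means these compounds.

Measured so far, in a functional assay on HCT-116 cells (Homo sapiens); a higher number here means a weaker inhibitor of growth, a lower number a stronger inhibitor of growth:
- compound 1, `Cc1cc(C)c2c(O)cc(-c3ccc(Cl)cc3)nc2n1`, gives 14800 nM
- compound 2, `Cc1ccnc2nc(-c3ccc(Cl)cc3)cc(O)c12`, gives 3720 nM
- compound 3, `COc1ccccc1-c1cc(O)c2ccc(C)nc2n1`, gives 38000 nM

Among these three, compound 3 sits at the highest number, and both of its gaps to the other two lie beyond the usual scatter of the measurement. How the core of compound 3 differs from the core of compound 1 is not broken down here; the two differ in more than one place.

Compounds 1 and 2 differ in one place only. The change is hydrogen in place of methyl on an aromatic carbon, and this step, a 4.0-fold lower number from compound 1 to compound 2 (0.60 log units; beyond the scatter), is modest but lies beyond the scatter, so removing that methyl made the inhibitor stronger.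

Compound 4, `COc1ccccc1-c1cc(O)c2cccnc2n1`, has not yet been measured. It stands to compound 3 as compound 2 stands to compound 1: the change is hydrogen in place of methyl on an aromatic carbon. It is the same kind of change, not exactly the same one, since in the pair of compound 1 and compound 2 the place is also described as meta to a methyl group, which is absent around the place in compound 3.

Among the measured compounds shown here, on that single earlier step, the expectation for the move from compound 3 to compound 4 in this assay is a 3.2-fold lower number from compound 3 to compound 4 (0.50 log units; beyond the scatter), kept somewhat short of the earlier one since only one example supports it. Compound 4 is therefore estimated at 12000 nM, with a likely range from 4500 nM to 32000 nM.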

Compound 4, concentration for 50% growth inhibition: 27500 nM
Beside the measured number, compound 4's estimate is 2.3-fold (0.36 log units) below it; the measured number falls inside the stated range.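

On the core of compound 3, putting hydrogen in place of methyl gives a 1.4-fold lower number from compound 3 to compound 4 (0.14 log units; within the scatter) in this assay, so on this core the two compounds cannot be told apart from ordinary repeat measurements. Set beside the earlier step, the same change does not carry over at the same size: the same change on two cores in this assay, a 4.0-fold lower number (0.60 log units; beyond the scatter) from compound 1 to compound 2 and a 1.4-fold lower number (0.14 log units; within the scatter) from compound 3 to compound 4, 2.9-fold (0.46 log units) apart, beyond the scatter of two such steps This shows that the stronger growth inhibition seen on the first core is not a fixed amount that can simply be transferred to another core, although two pairs cannot show which difference between the cores accounts for the mismatch, nor how the change would behave on a third core.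

From the compounds shown here alone, only methyl and hydrogen appear at this place, so it remains open how a longer chain such as ethyl, or a different group such as an amine or a chlorine atom, would behave there on either core. The cores of compound 1 and compound 3 differ in more than one place, so it also remains open which of those differences sets the size of the step, since no pair shown isolates any one of them.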